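A few compounds are considered here, and "the series" means these few. Any claim that something is new, unique, unknown or untested is made for them only; others in the source may bear on it.

Within the data shown here, in a functional assay on A549 cells (Homo sapiens) for antiproliferative activity, read by spectrophotometry, with a stated time of 2 days (a higher number here means a weaker inhibitor of growth, a lower number a stronger inhibitor of growth), compound 2 `COc1cc(Nc2ncc(C(F)(F)F)c(N3Cc4cccc(N(C)S(C)(=O)=O)c4C3)n2)c(OC)cc1Cl` gives 7300 nM, the only actual number so far. Compound 1 `COc1ccc(C(F)(F)F)cc1Nc1ncc(C(F)(F)F)c(N2Cc3cccc(N(C)S(C)(=O)=O)c3C2)n1` stands at > 30000 nM, which is a limit of the assay, as the limit of > 30000 nM in this assay, at which 1 of the 2 values shown sits, records. Compound 3 `Cc1cc(F)ccc1Nc1ncc(C(F)(F)F)c(N2Cc3cccc(N(C)S(C)(=O)=O)c3C2)n1` differs from compound 2 on a nitrogen on an aromatic ring: 4-fluoro-2-methylphenyl in place of 4-chloro-2,5-dimethoxyphenyl on a nitrogen on an aromatic ring. Among the measured compounds shown here, one measured step bears on this place, an at least 4.1-fold lower number from compound 1 to compound 2 (0.61 log units; beyond the scatter), and it lies beyond the scatter. On that single step, a change of similar size towards a higher number is expected in this assay, stated as the expected 2.2-fold higher number from compound 2 to compound 3 (0.34 log units; beyond the scatter). For compound 3 the estimated value is 16000 nM, with an expected range of 5000 nM to 30000 nM.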

Compound 3, concentration for 50% growth inhibition: > 30000 nM
Compound 3 was reported as a limit (the forecaster's own chance of this, stated with the estimate: 35%); middle value at least 1.8-fold (0.27 log units) from the limit.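

In this assay, 4-fluoro-2-methylphenyl in place of 4-chloro-2,5-dimethoxyphenyl on the nitrogen gives an at least 4.1-fold higher number from compound 2 to compound 3 (0.61 log units; beyond the scatter), so a second replacement of that group also ends without a measurable value. Compound 1 and compound 3 both stand at a limit, not a number: the limit of > 30000 nM in this assay, at which 2 of the 3 values shown sit. The step between those two cannot be read, so their groups cannot be ranked.

Still open, from the compounds shown here alone, is whether the chlorine or the methoxy groups of compound 2 matter more. Also open, going by these compounds, is whether a phenyl group carrying a morpholine or a carboxylic acid would give a lower number.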